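Adding a Methyl to the Cyclopropyl Ring of Compound 2

The source may report more compounds than this note shows. Statements on the series, on what has been measured and on what is new or still open speak of the compounds shown alone.

In an ADME assay on microsomes from liver (Rattus norvegicus) for pharmacokinetics (on this read-out higher numbers stand for fast clearance and lower numbers for slow clearance), compound 1 `C[C@@H]1CN(c2nc(-c3cnn(C)c3)ncc2C#N)CCN1C(=O)C1CCC1` gives < 36 mL/min/kg, which is a limit of the assay and not a number. Compound 2 `C[C@@H]1CN(c2cnc(C#N)c(-c3cnn(C)c3)n2)CCN1C(=O)C1CC1` gives < 36 mL/min/kg, and this too is a limit. Compound 3 `C[C@@H]1C[C@H]1C(=O)N1CCN(c2cnc(C#N)c(-c3cnn(C)c3)n2)C[C@H]1C` turns cyclopropyl into 2-methylcyclopropyl, with methyl in place of hydrogen on a saturated ring carbon. Among the measured compounds shown here, no measured pair shows what this change does, so the estimated step that the limit leaves unreadable from compound 2 to compound 3 is expected to stay within the usual scatter. For compound 3 the expected value in this assay is 30 mL/min/kg, with an estimated range from 14 mL/min/kg to 60 mL/min/kg.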

Compound 3, clearance in the Rattus norvegicus assay: 47 mL/min/kg
Compound 3: the middle estimate sits 1.6-fold (0.19 log units) below what was measured; the measured number falls inside the stated range.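

In the Rattus norvegicus assay compound 3, with the 2-methylcyclopropyl group, gives 47 mL/min/kg, a number and not a limit. In the Rattus norvegicus assay the change reads as an at least 1.3-fold higher number from compound 2 to compound 3 (0.11 log units; that floor lies within the scatter). The true size of this step stays unreadable because the value of compound 2 is a limit of the assay: the limit of < 36 mL/min/kg in the Rattus norvegicus assay, at which 2 of the 3 values shown sit. In a physicochemical assay for lipophilicity, read by HPLC (on this read-out lower numbers stand for lower lipophilicity and higher numbers for higher lipophilicity), compound 2 gives 1.8 and compound 3 gives 1.6. In the physicochemical assay the same change gives a number 0.20 log units lower from compound 2 to compound 3 (within the scatter).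

Going by these compounds, what a hydroxyl or an amine in place of this methyl on the cyclopropyl ring would do in either assay remains open.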